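The compounds below may be only part of what the source reports. "The series", "measured", "known", "first", "only" and "open" are said of these compounds alone.

Compound 3 `O=C(Nc1cc(Oc2ccc(Nc3nccc4[nH]cc(-c5ccc(F)cc5)c(=O)c34)cc2F)ccn1)C1CC1` sits at the top of the three numbers measured in a functional assay on MKN-45 cells (Homo sapiens) for antiproliferative activity, read by MTT assay, with a stated time of 72 h, tested at 10 uM (a lower number here means less inhibition, a higher number more inhibition at the concentration tested (going by the name of the read-out)), where compound 3 gives 81.8%. Compound 2 `CC(=O)Nc1cc(Oc2ccc(Nc3nccc4[nH]cc(-c5ccc(F)cc5)c(=O)c34)cc2F)ccn1` gives 77.1% in this assay, and compound 1 `CCn1cc(-c2ccc(F)cc2)c(=O)c2c(Nc3ccc(Oc4ccnc(NC(=O)C5CC5)c4)c(F)c3)nccc21` gives 31.9%. Of the two measured steps, a number 49.9 percentage points higher from compound 1 to compound 3 (beyond the scatter), while a number 4.7 percentage points higher from compound 2 to compound 3 (within the scatter). Compound 4 `CCC(=O)Nc1cc(Oc2ccc(Nc3nccc4[nH]cc(-c5ccc(F)cc5)c(=O)c34)cc2F)ccn1` differs from compound 3 by ethyl in place of cyclopropyl on a carbonyl carbon. Among the compounds with values here, the step that bears on this is the one from compound 2 to compound 3, which also changed the group on the carbonyl carbon and stayed within the scatter; the step from compound 1 to compound 3 concerns a different place. In this assay compound 4 is therefore expected to show a number 3.8 percentage points lower from compound 3 to compound 4 (within the scatter), with an estimated value of 78%, between 64% and 90%.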

Compound 4, a percentage reported as inhibition, at one concentration (the size of the read-out at that concentration, not a potency): 92.1%
Estimate against measurement, compound 4: 14.1 percentage points below, outside the stated range (above it).
By their numbers in this assay, from the lowest: compound 1; then compounds 2 and 3 (each within the scatter of the next); then compound 4.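

Within the data shown here, at this place in this assay, the group on the carbonyl carbon does matter: ethyl in place of cyclopropyl gives a number 10.3 percentage points higher from compound 3 to compound 4 (beyond the scatter) and no earlier step at this place went beyond the scatter. Methyl in place of hydrogen on the saturated chain carbon bound to the carbonyl carbon gives a number 15 percentage points higher from compound 2 to compound 4 (beyond the scatter) so ethyl stands above both methyl and cyclopropyl here. Nothing shown gives a reason for these differences. On these data alone, whether a longer chain, or a chain carrying an amine, would raise or lower the inhibition remains open.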